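The source may hold more compounds than are shown below. What is called first, only, known or untested is meant among the compounds shown, and "the series" means these compounds.

Compound 1 `COc1ccccc1C(=O)NC(=O)Nc1ccc(-c2ccccc2)c(C(F)(F)F)c1` is a urea bearing a 2-methoxyphenyl carbonyl and a biphenyl with a trifluoromethyl group. In an ADME assay on LLC-PK1 cells (Sus scrofa) for permeability (on this read-out lower numbers stand for lower permeability and higher numbers for higher permeability), compound 1 gives < 1 10^-6 cm/s, which is a limit of the assay and not a number; compound 1 thus sits at the limit of < 1 10^-6 cm/s in this assay, at which 1 of the 3 values shown sits. Compound 2 `COc1ccccc1C(=O)NC(=O)Nc1ccc(-c2nccs2)c(C(F)(F)F)c1` gives 12 10^-6 cm/s in this assay, and compound 3 `COc1ccccc1C(=O)NC(=O)Nc1ccc(-c2ccccn2)c(C(F)(F)F)c1` gives 7.4 10^-6 cm/s. The steps are an at least 12-fold higher number from compound 1 to compound 2 (1.07 log units; beyond the scatter) and an at least 7.4-fold higher number from compound 1 to compound 3 (0.86 log units; beyond the scatter), while a 1.6-fold lower number from compound 2 to compound 3 (0.21 log units; within the scatter). Compound 4 `COc1ccncc1C(=O)NC(=O)Nc1ccc(-c2ccccc2)c(C(F)(F)F)c1` differs from compound 1 by 4-methoxypyridin-3-yl in place of 2-methoxyphenyl on a carbonyl carbon. This change touches a different ring than the measured steps, but each of those steps put a nitrogen into an aromatic ring and raised the number beyond the scatter, so a rise of uncertain size seems likely for compound 4 as well. Compound 4 is expected to show an at least 4.0-fold higher number from compound 1 to compound 4 (0.60 log units; beyond the scatter). Compound 4 is therefore estimated at 4 10^-6 cm/s, with a range from 1 10^-6 cm/s to 12 10^-6 cm/s.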

Compound 4, apparent permeability: 2.3 10^-6 cm/s
Compound 4: the middle estimate sits 1.7-fold (0.24 log units) above what was measured; the range from low to high includes it.
By their numbers in this assay, from the lowest: compound 4; then compounds 3 and 2 (each within the scatter of the next). At a limit, below all of these: compound 1.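

In this assay, the ring on the carbonyl carbon also responds to this change, with an at least 2.3-fold higher number from compound 1 to compound 4 (0.36 log units; beyond the scatter). For the compounds shown here, a ring nitrogen in 4-methoxypyridin-3-yl thus goes with a step beyond the scatter at this position too, whereas the earlier steps changed only the group replacing phenyl. The true size of the step stays unknown because compound 1 stands at a limit of the assay and not at a number: the limit of < 1 10^-6 cm/s in this assay, at which 1 of the 4 values shown sits.

Going by these compounds, it remains open whether 4-methoxypyridin-3-yl combined with 1,3-thiazol-2-yl or pyridin-2-yl would raise the number further. Also open, on these data alone, is how an amine or a carboxylic acid in place of the methoxy group would read.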